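The source may report more compounds than this note shows. Statements on the series, on what has been measured and on what is new or still open speak of the compounds shown alone.

Compound 1 `COc1ccc(S(=O)(=O)c2ccc(NC(=O)C(C)(O)C(F)(F)F)cc2)cc1`, > 30000 nM
Compound 2 `CC(O)(C(=O)Nc1ccc(S(=O)(=O)N(c2ccccc2)c2ccccc2)cc1)C(F)(F)F`, > 30000 nM
Compound 3 `CC(O)(C(=O)Nc1ccc(C(=O)c2cccc(F)c2)cc1)C(F)(F)F`, 2600 nM

Three compounds share a core carrying a trifluoromethyl-bearing hydroxy amide and have been measured in a functional assay (Cavia porcellus) with sulfonylurea receptors; K-ATP channels (Homo sapiens) as the target; a higher number here means a weaker inhibitor, a lower number a stronger inhibitor. In this assay compound 1 gives only a limit, > 30000 nM, and no number. Compound 2 likewise gives only a limit, > 30000 nM. Among the compounds with values here, compound 3 is the one compound that returns a number, 2600 nM. Compound 1 therefore stands at the weak end of what has been seen: at the limit of > 30000 nM in this assay, at which 2 of the 3 values shown sit, where compound 2 sits as well, while compound 3 alone lies inside the measurable range.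

Compound 4 `CC(O)(C(=O)Nc1ccc(S(=O)(=O)c2ccccn2)cc1)C(F)(F)F` has not yet been measured. It differs from compound 1 in one place: pyridin-2-yl in place of 4-methoxyphenyl on a sulfonyl sulfur. Within the data shown here, no two of the measured compounds differ from each other in just one place, so no measured step shows what such a change does here. With compound 1 known only as a limit, the step from a number no higher from compound 1 to compound 4 (the limit leaves the size open) is expected to be small, in no direction beyond the usual scatter. Compound 4 is thus estimated to give 30000 nM in this assay, with a range from 8000 nM to 100000 nM, and a fair chance that only a limit is reported again.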

Compound 4, half-maximal inhibitory concentration: 600 nM
Estimate against measurement, compound 4: 50-fold (1.70 log units) above, and the stated range ends above it.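

In this assay, within the data shown here, the group on the sulfonyl sulfur turns out to matter strongly: pyridin-2-yl in place of 4-methoxyphenyl gives an at least 50-fold lower number from compound 1 to compound 4 (1.69 log units; beyond the scatter), the first step that can be read. The change swaps a ring of carbon only, carrying a methoxy group, for a smaller ring with one hetero atom, while the counts of hydrogen-bond donors and acceptors stay the same and neither group has a net charge, so a change that leaves those counts untouched is enough to bring a compound from the limit into the measurable range. The true size of the step stays open on one side, as compound 1 is known only as a limit and not as a number: the limit of > 30000 nM in this assay, at which 2 of the 4 values shown sit.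

The compounds shown leave open whether the step comes from the ring nitrogen of pyridin-2-yl or from the loss of the methoxy group, since both change at once, and a plain phenyl on the same sulfonyl sulfur would separate the two. They also leave open whether the place of that nitrogen counts, which pyridin-3-yl would address, and they give no reason for the effect.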